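Nitro for bromo on the aryl ketone of the series

The source may report more compounds than this note shows. Statements on the series, on what has been measured and on what is new or still open speak of the compounds shown alone.

Compound 1, `COc1cc(-c2nnc3n2NC(c2ccco2)C(C(=O)c2ccc(Br)cc2)S3)cc(OC)c1OC`: in a functional assay on HepG2 cells (Homo sapiens) for cytotoxicity, read by MTT assay, with a stated time of 48 h (a lower number here means a stronger inhibitor, a higher number a weaker inhibitor), compound 1 gives only a limit, > 100000 nM.
Compound 2, `COc1ccc(C(=O)C2Sc3nnc(-c4cc(OC)c(OC)c(OC)c4)n3NC2c2ccco2)cc1`: in this assay compound 2 gives only a limit, > 100000 nM.
Compound 3, `COc1cc(-c2nnc3n2NC(c2ccco2)C(C(=O)c2ccc(C(F)(F)F)cc2)S3)cc(OC)c1OC`: in this assay compound 3 gives only a limit, > 100000 nM.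

Compound 1 therefore stands at a limit in this assay and no number is known for it. The same holds across the set: the limit of > 100000 nM in this assay, at which 3 of the 3 values shown sit.

Compound 4, `COc1cc(-c2nnc3n2NC(c2ccco2)C(C(=O)c2ccc([N+](=O)[O-])cc2)S3)cc(OC)c1OC`, is not yet measured. It differs from compound 1 by nitro in place of bromo on an aromatic carbon, the change sitting on the same aromatic carbon that carried the bromo, methoxy and trifluoromethyl of the measured compounds.

Among the measured compounds shown here, the steps that bear on this change are a step that the two limits leave unreadable from compound 1 to compound 2, a step that the two limits leave unreadable from compound 1 to compound 3 and a step that the two limits leave unreadable from compound 2 to compound 3. None of them is readable, since every value involved is a limit, so no size or direction can be drawn from them for this assay. The only expectation the data support is that compound 4 behaves like the measured three and remains at the limit.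

The expected step is a number no higher from compound 1 to compound 4 (the limit leaves the size open), which is estimated as no change beyond the scatter. Compound 4 is estimated at 100000 nM, with a range from 30000 nM to 300000 nM, and most likely only a limit will be reported.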

Compound 4, half-maximal inhibitory concentration: 87800 nM
Estimate against measurement, compound 4: 1.1-fold (0.06 log units) above, and the stated range covers the measured number.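

In this assay, among the compounds shown here, compound 4 gives 87800 nM, the first actual number at this aromatic carbon.

The other three compounds of the set are held at an assay limit: the limit of > 100000 nM in this assay, at which 3 of the 4 values shown sit.

The readable steps are an at least 1.1-fold lower number from compound 1 to compound 4 (0.05 log units; that floor lies within the scatter) with bromo leaving, an at least 1.1-fold lower number from compound 3 to compound 4 (0.05 log units; that floor lies within the scatter) with trifluoromethyl leaving and an at least 1.1-fold lower number from compound 2 to compound 4 (0.05 log units; that floor lies within the scatter) with methoxy leaving. Each floor lies within the scatter, so the 4-nitrophenyl ketone yields a number but is not shown to stand apart from the other three compounds.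

From the compounds shown here alone, the steps among compound 1, compound 2 and compound 3 cannot be read, and how far those three lie from compound 4 remains open. Also open, going by these compounds, is whether an amine or a carboxylic acid on this aromatic carbon would give a step beyond the scatter from compound 4.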